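Tert-Butyl for Methyl on the Shared Core

A few compounds are considered here, and "the series" means these few. Any claim that something is new, unique, unknown or untested is made for them only; others in the source may bear on it.

compound 1 `CCN1CCc2c(c(C)nn2C(=O)Nc2ccc(F)cc2F)C1`: 7.8%
compound 2 `CCN1CCc2c(c(C)nn2C(=O)Nc2cc(C)ccc2F)C1`: 5.2%

In a functional assay on the whole organism (strain Swiss albino) for inhibition, with Mus musculus as the target, in the formalin test, with stated times of 30 min and 5 min, at a dose of 100 mg/kg (a higher number here means more inhibition at the dose given (going by the name of the read-out), a lower number less inhibition), compound 2 gives 5.2%, the smaller of the two numbers shown, though its gap to compound 1 lies within the usual scatter; compound 1 gives 7.8%. Compound 3 `CCN1CCc2c(c(C(C)(C)C)nn2C(=O)Nc2cc(C)ccc2F)C1` differs from compound 2 by tert-butyl in place of methyl on an aromatic carbon. For the measured compounds named here, no step between measured compounds bears on this change, so its size is not known from the data. Both measured values are small. Compound 3 is expected to stay in that region, with the step of a number 2.8 percentage points higher from compound 2 to compound 3 (within the scatter) estimated as none beyond the scatter. Compound 3 is estimated at 8% in this assay, within 0% to 25%.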

Compound 3, a percentage reported as inhibition, in the whole organism at one dose (the size of the read-out at that dose, not a potency): 7%
For compound 3 the middle estimate is 1 percentage points above the measured one, within the range that was stated.
By their numbers in this assay, from the lowest: compounds 2, 3 and 1 (each within the scatter of the next).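

In this assay, tert-butyl in place of methyl on an aromatic carbon gives a number 1.8 percentage points higher from compound 2 to compound 3 (within the scatter), the first step read at this position. The change from methyl to tert-butyl therefore leaves the read-out within the scatter, and the inhibition at this dose stays small. Nothing available explains this outcome. On these data alone, what remains open is whether a different group at this position, such as an amine or a carboxylic acid, would give a step beyond the scatter.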